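Quinolin-3-yl for 4-chlorophenyl on the enaminone nitrogen

This account rests on a few compounds, and the source may have more. Where it says the series, first, only, none or still open, it means among the compounds named here.

Two members of the series have been measured in a functional assay on MDA-MB-231 cells (Homo sapiens) for cytotoxicity, read by MTT assay, with a stated time of 48 h; on this read-out higher numbers stand for weaker inhibition and lower numbers for stronger inhibition. Compound 1 `O=C(/C=C\Nc1cnc2ccccc2c1)c1nc(-c2ccccc2)n2ccccc12` gives 12300 nM. Compound 2 `O=C(/C=C\Nc1ccc(Cl)cc1)c1nc(-c2ccc(C(F)(F)F)cc2)n2ccccc12` gives 3840 nM in this assay, the lower of the two numbers, and the gap to compound 1 lies beyond the scatter. Compound 1 and compound 2 differ in two places at once, so nothing can be assigned to either place alone.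

Compound 3 `O=C(/C=C\Nc1cnc2ccccc2c1)c1nc(-c2ccc(C(F)(F)F)cc2)n2ccccc12` is not yet measured. It differs from compound 2 in one place: quinolin-3-yl in place of 4-chlorophenyl on an amine nitrogen. The group that enters is the same amine substituent carried by compound 1, while the trifluoromethyl-bearing aryl of compound 2 is kept, so compound 3 sits between the two measured compounds in structure.

Among the compounds with values here, no single-change step is available to size this exchange. In this assay the expectation is a modest rise in the number from compound 2, a 1.8-fold higher number from compound 2 to compound 3 (0.26 log units; within the scatter), toward the value of compound 1 but not reaching it. Compound 3 is therefore expected to give 7000 nM, within a range of 2500 nM to 20000 nM.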

Compound 3, half-maximal inhibitory concentration: > 30000 nM
Compound 3: no number, only a limit; the forecaster's own chance of this, stated with the estimate: 5%; at least 4.2-fold (0.63 log units) between middle value and limit.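

Compound 3 stands as a limit of the assay and not as a number: the limit of > 30000 nM in this assay, at which 1 of the 3 values shown sits.

Within the data shown here, with the trifluoromethyl-bearing aryl kept, quinolin-3-yl in place of 4-chlorophenyl on the amine nitrogen gives an at least 7.8-fold higher number from compound 2 to compound 3 (0.89 log units; beyond the scatter), the first single-place reading at this position in this assay, and only its minimum size is known. With quinolin-3-yl kept, trifluoromethyl in place of hydrogen on an aromatic carbon gives an at least 2.4-fold higher number from compound 1 to compound 3 (0.38 log units; beyond the scatter), so on this amine substituent the added trifluoromethyl does not lower the number, and among the three compounds the lowest number goes with 4-chlorophenyl on the amine nitrogen, in compound 2.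

The compounds shown leave open how far the number of compound 3 lies past its limit, and whether trifluoromethyl raises or lowers the number when 4-chlorophenyl stays on the amine nitrogen. They also leave open whether the rise follows the added fused ring or the ring nitrogen of quinolin-3-yl, or the loss of chlorine, a question that plain phenyl, pyridin-3-yl or naphthalen-2-yl on the amine nitrogen would address.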